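Cyclohexyl ketone analogue and cytotoxicity on mouse fibroblasts

The compounds below may be only part of what the source reports. "The series", "measured", "known", "first", "only" and "open" are said of these compounds alone.

Compound 1 `O=[N+]([O-])c1ccc(Sc2cn(-c3ccc4c(c3)B(O)OC4)c3ccccc23)cc1`: > 10 ug/mL
Compound 2 `Cc1ccc(C(=O)c2ccn(-c3ccc4c(c3)B(O)OC4)c2)cc1`: > 10 ug/mL
Compound 3 `Cc1ccccc1C(=O)c1ccn(-c2ccc3c(c2)B(O)OC3)c1`: > 10 ug/mL

Of the compounds shown here, three with a shared core have been tested in an ADME assay on L929 cells (Mus musculus) for cytotoxicity, read by resazurin assay, with a stated time of 72 h; on this read-out lower numbers stand for stronger inhibition and higher numbers for weaker inhibition. Compound 1 reaches only the limit of this assay, > 10 ug/mL, which is not a number. Compound 2 also gives only a limit in this assay, > 10 ug/mL. Compound 3 stands at a limit as well in this assay, > 10 ug/mL, so its place among the three cannot be told more closely. The measured step that the two limits leave unreadable from compound 2 to compound 3 is accordingly not readable in size or direction; all that is known is the limit of > 10 ug/mL in this assay, at which 3 of the 3 values shown sit.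

Compound 4 `O=C(c1ccn(-c2ccc3c(c2)B(O)OC3)c1)C1CCCCC1` differs from compound 3 in one place: cyclohexyl in place of 2-methylphenyl on a carbonyl carbon. Among the measured compounds shown here, the only step on this carbonyl carbon, the one from compound 2 to compound 3, is unreadable, so no shift beyond the scatter of this assay is expected here, and the expected step that the limit leaves unreadable from compound 3 to compound 4 is none beyond the scatter. Compound 4 is therefore estimated at 15 ug/mL, within 7 ug/mL to 50 ug/mL, most likely again reported only as a limit.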

Compound 4, half-maximal inhibitory concentration: > 10 ug/mL
Compound 4 ended at the assay's limit; the forecaster's own chance of this, stated with the estimate: 80%; the middle value does not contradict the limit.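

In this assay compound 4 gives > 10 ug/mL, which is a limit and not a number, so the steps to compound 4 from compound 2 and compound 3 cannot be read: the limit of > 10 ug/mL in this assay, at which 4 of the 4 values shown sit.

The compounds shown leave open whether cyclohexyl, 2-methylphenyl or 4-methylphenyl on the carbonyl carbon makes any difference to cytotoxicity.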